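The compounds below may be only part of what the source reports. "The series", "measured", "known", "first", "only" and "open" are said of these compounds alone.

Working notes on the series. Compound 1 `CC1=NN(C(=O)CN2CCCC2)C(c2ccccc2O)C1`, compound 2 `CC(=O)Oc1ccccc1C1CC(C)=NN1C(=O)CN1CCC(C(C)=O)CC1` and compound 3 `O=C(CCl)N1N=C(c2cc3ccccc3oc2=O)CC1c1ccccc1` have been tested in a functional assay on HepG2 cells (Homo sapiens) for cytotoxicity, read by MTT assay, with a stated time of 48 h; a lower number here means a stronger inhibitor, a higher number a weaker inhibitor. In this assay compound 1 gives 5540 nM, compound 2 gives 7800 nM and compound 3 gives 2980 nM. Compound 3 has the lowest number of the three; its gap to compound 1 lies within the scatter, its gap to compound 2 beyond it. Compound 4 `CN1CCN(CC(=O)N2N=C(c3cc4ccccc4oc3=O)CC2c2ccccc2)CC1` is not yet measured. It differs from compound 3 by 4-methylpiperazin-1-yl in place of chloro on a saturated chain carbon bound to a carbonyl carbon. A rise in the number of moderate size, a 2.0-fold higher number from compound 3 to compound 4 (0.30 log units; within the scatter), is expected, since compound 1 and compound 2 carry amines at that place and give higher numbers. Compound 4 is therefore estimated at 6000 nM, within 2500 nM to 15000 nM.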

Compound 4, half-maximal inhibitory concentration: 33100 nM
Compound 4: middle estimate off by 5.5-fold (0.74 log units), on the low side; measured number above the stated range.
By their numbers in this assay, from the lowest: compounds 3, 1 and 2 (each within the scatter of the next, the first and the last beyond it); then compound 4.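

With the shared core held fixed, the group on a saturated chain carbon bound to a carbonyl carbon strongly affects the result: in this assay 4-methylpiperazin-1-yl in place of chloro gives an 11-fold higher number from compound 3 to compound 4 (1.05 log units; beyond the scatter) on this change alone. Compound 1 and compound 2 differ from compound 3 in more than one place, so they could not isolate this position. No available evidence bears on the reason for this step. Open, going by these compounds, is how a dimethylamino or morpholin-4-yl group at the same place would compare with chloro and 4-methylpiperazin-1-yl on this core.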